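Two benzyl triazoles at the assay limit, a third to come

This account rests on a few compounds, and the source may have more. Where it says the series, first, only, none or still open, it means among the compounds named here.

Compound 1, `O=C1N[C@H]2[C@H](CS[C@H]2CCCCCc2cn(Cc3cccc(C(F)(F)F)c3)nn2)N1`: > 16000 nM
Compound 2, `O=C1N[C@H]2[C@H](CS[C@H]2CCCCCc2cn(Cc3ccccc3Br)nn2)N1`: > 16000 nM

In an assay on isolated protein for inhibition of biotin--protein ligase (Homo sapiens), read by scintillation counting, with a stated time of 10 min (on this read-out higher numbers stand for weaker inhibition and lower numbers for stronger inhibition), compound 1 gives > 16000 nM, which is a limit of the assay and not a number. In this assay compound 2 gives > 16000 nM, also a limit. The step that the two limits leave unreadable from compound 1 to compound 2 therefore cannot be read. Where compound 2 stands is known only as a limit, shared with the one other value shown, as the limit of > 16000 nM in this assay, at which 2 of the 2 values shown sit, records. Compound 3, `O=C1N[C@H]2[C@H](CS[C@H]2CCCCCc2cn(Cc3ccc(Cl)cc3)nn2)N1`, differs from compound 2 by 4-chlorophenyl in place of 2-bromophenyl on a saturated chain carbon bound to an aromatic nitrogen. Among the measured compounds shown here, the single measured step bears on this change only in that both of its ends are limits, so it offers neither a direction nor a size. Compound 3 is accordingly expected to sit at the same limit, with an estimate of 20000 nM and a range from 8000 nM to 60000 nM. The step expected is a step that the limit leaves unreadable from compound 2 to compound 3, nothing beyond the scatter.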

Compound 3, inhibition constant: > 16000 nM
Compound 3 ended at the assay's limit; the forecaster's own chance of this, stated with the estimate: 80%; the middle value is on the limit's open side.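

Among the compounds shown here, compound 1, compound 2 and compound 3 all stand at a limit in this assay, not at a number, so no step among them can be read. The compounds shown leave open how far these three differ, and whether any of them inhibits measurably.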